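A few compounds are considered here, and "the series" means these few. Any claim that something is new, unique, unknown or untested is made for them only; others in the source may bear on it.

Compound 3 `CNC(=O)c1cc(C(=O)N[C@H]2CC[C@H](O)CC2)n([C@@H](C)c2cccc(C(F)(F)F)c2)n1` gives 280 nm/s in an ADME assay for permeability; on this read-out higher numbers stand for higher permeability and lower numbers for lower permeability; its step from compound 1 `CNC(=O)c1cc(C(=O)N[C@H]2CC[C@H](O)CC2)n([C@@H](C)c2ccc(Cl)cc2)n1`, which gives 180 nm/s, is a 1.6-fold higher number from compound 1 to compound 3 (0.19 log units; within the scatter), within the scatter, while its step from compound 2 `CNC(=O)c1cc(C(=O)N[C@H]2CC[C@H](O)CC2)n([C@@H](C)c2cccc(C)c2)n1`, which gives 110 nm/s, is a 2.5-fold higher number from compound 2 to compound 3 (0.41 log units; beyond the scatter), beyond it. Compound 4 `CNC(=O)c1cc(C(=O)N[C@H]2CC[C@H](O)CC2)n([C@@H](C)c2ccc(C(F)(F)F)cc2)n1` differs from compound 3 by 4-(trifluoromethyl)phenyl in place of 3-(trifluoromethyl)phenyl on a saturated chain carbon bound to an aromatic nitrogen and a saturated chain carbon. The measured steps that exchange one phenyl substituent for another, a 1.6-fold lower number from compound 1 to compound 2 (0.21 log units; within the scatter) and a 1.6-fold higher number from compound 1 to compound 3 (0.19 log units; within the scatter), both stay within the scatter; only a 2.5-fold higher number from compound 2 to compound 3 (0.41 log units; beyond the scatter), which keeps the substituent and alters its kind, exceeds it. Since the trifluoromethyl group itself is retained here, no step beyond the scatter is expected in this assay, the estimated step being a 1.1-fold lower number from compound 3 to compound 4 (0.03 log units; within the scatter). Compound 4 is expected to give 260 nm/s, within a range of 150 nm/s to 450 nm/s.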

Compound 4, apparent permeability in the ADME assay: 270 nm/s
Beside the measured number, compound 4's estimate is 1.0-fold (0.02 log units) below it; the range from low to high includes it.
By their numbers in the ADME assay, from the lowest: compounds 2, 1, 4 and 3 (each within the scatter of the next, the first and the last beyond it).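

Moving the trifluoromethyl group around the phenyl ring does not separate the two compounds in the ADME assay (a 1.0-fold lower number from compound 3 to compound 4 (0.02 log units; within the scatter)), and compound 4 sits as compound 3 does against the other two, with a 2.5-fold higher number from compound 2 to compound 4 (0.39 log units; beyond the scatter) and a 1.5-fold higher number from compound 1 to compound 4 (0.18 log units; within the scatter). In a physicochemical assay for solubility, measured as kinetic solubility (a lower number here means a less soluble compound, a higher number a more soluble compound), compound 3 gives 7 ug/mL. In the physicochemical assay compound 4 gives >= 175 ug/mL, which is a limit of the assay and not a number.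

On these data alone, whether an amine or a carboxylic acid in place of trifluoromethyl on the phenyl ring would hold both read-outs stays open.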